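Ortho substituent on the benzyl arm: methyl to methoxy

The compounds below may be only part of what the source reports. "The series", "measured", "known", "first", "only" and "open" are said of these compounds alone.

Compound 1 `Clc1cccc(-n2ncnc2NCc2ccccc2)c1Cl` is the unsubstituted benzyl member of the series; in a functional assay for antagonist activity at P2X purinoceptor 7 (Rattus norvegicus), read by FLIPR and calcium flux (on this read-out higher numbers stand for weaker inhibition and lower numbers for stronger inhibition), compound 1 gives 209 nM. Compound 2 `Cc1ccccc1CNc1ncnn1-c1cccc(Cl)c1Cl` carries methyl in place of hydrogen on an aromatic carbon, and in this assay compound 2 gives 200 nM. The step of a 1.0-fold lower number from compound 1 to compound 2 (0.02 log units; within the scatter) lies within the scatter, so compound 2 stands indistinguishable from compound 1 on this read-out; no separation between the two numbers can be claimed.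

Compound 3 `COc1ccccc1CNc1ncnn1-c1cccc(Cl)c1Cl` differs from compound 2 by methoxy in place of methyl on an aromatic carbon. Among the measured compounds shown here, the only measured step touching this position is the one from compound 1 to compound 2, and it produced nothing beyond the scatter. No oxygen-bearing group at that place has been measured, so the expectation rests on that single flat step.

The number for compound 3 in this assay is estimated at 220 nM, with a range of 90 nM to 550 nM. The step this estimate means for compound 3 is expected to be a 1.1-fold higher number from compound 2 to compound 3 (0.04 log units; within the scatter), nothing beyond the usual scatter.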

Compound 3, half-maximal inhibitory concentration: 708 nM
Compound 3: the middle estimate sits 3.2-fold (0.51 log units) below what was measured; measured number above the stated range.
By their numbers in this assay, from the lowest: compounds 2 and 1 (each within the scatter of the next); then compound 3.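

In this assay this position is not indifferent to the group it carries: methoxy in place of methyl gives a 3.5-fold higher number from compound 2 to compound 3 (0.55 log units; beyond the scatter) and methoxy in place of hydrogen gives a 3.4-fold higher number from compound 1 to compound 3 (0.53 log units; beyond the scatter) on the same read-out. The flat exchange of hydrogen for methyl therefore does not extend to methoxy, and compound 3, the only one of the three with an oxygen at this place, is the only one separated from the others. Nothing on hand accounts for this higher number.

Open, on these data alone, is whether the higher number goes with the oxygen atom or with the two heavy atoms of methoxy; ethyl or hydroxy at the same place would tell these apart. Also open, as far as these compounds go, is how an amine or a carboxylic acid would read there.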